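From methoxycarbonyl to benzyloxycarbonyl in a cell toxicity test

A few compounds are considered here, and "the series" means these few. Any claim that something is new, unique, unknown or untested is made for them only; others in the source may bear on it.

Among the measured compounds shown here, in a functional assay on HEL cells (Homo sapiens) (on this read-out higher numbers stand for lower toxicity in this test and lower numbers for higher toxicity in this test), compound 2 `COC(=O)CNC1=CS(=O)(=O)O[C@@]12[C@@H](CO[Si](C)(C)C(C)(C)C)O[C@@H](n1cc(C)c(=O)n(C)c1=O)[C@@H]2O[Si](C)(C)C(C)(C)C` gives 160000 nM, the only exact number available so far. In this assay, compound 1 `Cc1cn([C@@H]2O[C@@H]3COC(=O)[C@]3(OS(C)(=O)=O)[C@H]2O)c(=O)[nH]c1=O` gives >= 36000 nM, which is a limit of the assay and not a number.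

Compound 3 `Cc1cn([C@@H]2O[C@H](CO[Si](C)(C)C(C)(C)C)[C@@]3(OS(=O)(=O)C=C3NCC(=O)OCc3ccccc3)[C@H]2O[Si](C)(C)C(C)(C)C)c(=O)n(C)c1=O` differs from compound 2 in one place: phenyl in place of hydrogen on a saturated chain carbon bound to an oxygen next to a carbonyl group. Phenyl takes the place of hydrogen on a saturated chain carbon bound to an oxygen next to a carbonyl group, so methoxycarbonyl becomes benzyloxycarbonyl. For the measured compounds named here, no measured pair of compounds shows what this change does. The expectation in this assay is therefore no shift beyond the usual scatter, in either direction. The expected step of a 1.3-fold lower number from compound 2 to compound 3 (0.12 log units; within the scatter) is small. For compound 3 the estimated value is 120000 nM, with an expected range of 50000 nM to 280000 nM.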

Compound 3, half-maximal cytotoxic concentration: > 200000 nM
Compound 3 was reported as a limit (the forecaster's own chance of this, stated with the estimate: 45%); middle value at least 1.6-fold (0.22 log units) away from the limit.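

Compound 3 gives > 200000 nM in this assay, which is a limit of the assay and not a number. Going from methoxycarbonyl to benzyloxycarbonyl gives an at least 1.2-fold higher number from compound 2 to compound 3 (0.09 log units; that floor lies within the scatter), so this first measured change at this place shows no sign of higher toxicity in this test, even with a whole phenyl on the saturated chain carbon. The true size of the step cannot be read, as the result stops at the end of the measurable range: the limit of > 200000 nM in this assay, at which 1 of the 3 values shown sits.

Open, from the compounds shown here alone, is how large the step really is, and whether a different group at this place, such as an ethyl, a longer chain or a chain ending in an amine, would behave the same way. Compound 1 differs from compound 2 and compound 3 in more than one place, so it cannot settle either question.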